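The source may hold more compounds than are shown below. What is called first, only, known or untested is meant among the compounds shown, and "the series" means these compounds.

Compound 1 `CCCCNC(=O)COc1ccc(C(=O)c2c(CCCC)oc3ccccc23)cc1`, compound 2 `CCCCc1oc2ccccc2c1C(=O)c1ccc(OCC(=O)Nc2cccc(OC)c2)cc1` and compound 3 `CCCCc1oc2ccccc2c1C(=O)c1ccc(OCC(=O)N[C@@H](C)c2ccccc2)cc1` share one core and differ only in the group on an amide-type nitrogen. In a functional assay on HL-60 cells (Homo sapiens) for antiproliferative activity, read by MTT assay, with a stated time of 24 h (a lower number here means a stronger inhibitor, a higher number a weaker inhibitor), compound 1 gives > 50000 nM, which is a limit of the assay and not a number. Compound 2 gives > 50000 nM, again a limit. Compound 3 gives > 50000 nM, also a limit. Every result so far is therefore the same: the limit of > 50000 nM in this assay, at which 3 of the 3 values shown sit.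

The measured steps offer no size to work with. There is a step that the two limits leave unreadable from compound 1 to compound 2, a step that the two limits leave unreadable from compound 1 to compound 3 and a step that the two limits leave unreadable from compound 2 to compound 3.

Compound 4 `CCCCc1oc2ccccc2c1C(=O)c1ccc(OCCCC(=O)N2CCCC2)cc1` differs from compound 3 in this way: 2-((pyrrolidin-1-yl)carbonyl)ethyl in place of (1-phenylethyl)carbamoyl on a saturated chain carbon bound to an oxygen on an aromatic ring. In words, 2-((pyrrolidin-1-yl)carbonyl)ethyl stands in place of (1-phenylethyl)carbamoyl on a saturated chain carbon bound to an oxygen on an aromatic ring. The measured steps only changed the group on the nitrogen, so they bear on this change loosely, and no direction can be read from them. The likeliest outcome for compound 4 is what compound 3 shows, because compound 3 reads > 50000 nM, a limit like the others.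

The expected change is small, and the estimate is a number no higher from compound 3 to compound 4 (the limit leaves the size open). For compound 4 the estimated value is 50000 nM, with an expected range from 20000 nM to 100000 nM.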

Compound 4, half-maximal inhibitory concentration: 29900 nM
For compound 4 the middle estimate is 1.7-fold (0.22 log units) above the measured one; low and high end bracket the measured number.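

In this assay compound 4 is the only one of the four compounds that gives a number rather than a limit of the assay, while the other three share that one limit: the limit of > 50000 nM in this assay, at which 3 of the 4 values shown sit.

Placing 2-((pyrrolidin-1-yl)carbonyl)ethyl on the saturated chain carbon bound to an oxygen on an aromatic ring therefore gives the first steps that can be read at all: an at least 1.6-fold lower number from compound 3 to compound 4 (0.22 log units; that floor lies within the scatter), an at least 1.6-fold lower number from compound 2 to compound 4 (0.22 log units; that floor lies within the scatter) and an at least 1.6-fold lower number from compound 1 to compound 4 (0.22 log units; that floor lies within the scatter). As far as these compounds go, each of these is only a floor, so the real size stays unknown, and nothing here shows a shift beyond the usual scatter.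

The change also does several things at once: a six-membered aromatic ring leaves in the case of compound 3, a five-membered non-aromatic ring enters, and the amide hydrogen is gone. Which of these parts matters stays open among the compounds shown, and so does how a piperidine amide or a carboxylic acid in the same place would read in this assay.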